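Removing a fluoro from compound 1: an expected cytotoxicity value

The source may report more compounds than this note shows. Statements on the series, on what has been measured and on what is new or still open speak of the compounds shown alone.

Of the compounds shown here, three sharing one core have been tested in a functional assay on HT-29 cells (Homo sapiens) for cytotoxicity, read by MTT assay, with a stated time of 2 days; a lower number here means a stronger inhibitor, a higher number a weaker inhibitor. Compound 1 `CCCCCNc1nc(NCc2ccco2)c2cc(F)ccc2n1` gives 4030 nM. Within the data shown here, compound 3 `COc1ccc(Nc2nc(NCc3ccco3)c3cc(F)ccc3n2)cc1` gives 4340 nM, and the only change between them, 4-methoxyphenyl in place of pentyl on a nitrogen on an aromatic ring, gave a 1.1-fold higher number from compound 1 to compound 3 (0.03 log units; within the scatter). Compound 2 `Cc1cccc(N2CCN(CCCCNc3nc(NCc4ccco4)c4ccccc4n3)CC2)c1C` gives 860 nM; it differs from compound 1 in more than one place, so its number cannot be tied to any single change. On the numbers shown, compound 1 stands second highest of the three, close to compound 3 and well apart from compound 2.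

Compound 4 `CCCCCNc1nc(NCc2ccco2)c2ccccc2n1` is not yet measured. It differs from compound 1 by hydrogen in place of fluoro on an aromatic carbon. Among the measured compounds shown here, no measured step isolates this change; the one measured single-site step concerned a different position and stayed within the scatter. For that reason no step beyond the scatter is expected, and a 1.0-fold lower number from compound 1 to compound 4 (0.00 log units; within the scatter) is the estimate. Compound 4 is expected to give 4000 nM, within 1500 nM to 11000 nM.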

Compound 4, half-maximal inhibitory concentration: 6730 nM
Compound 4: middle estimate off by 1.7-fold (0.23 log units), on the low side; the measured number falls inside the stated range.
By their numbers in this assay, from the lowest: compound 2; then compounds 1, 3 and 4 (each within the scatter of the next).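

In this assay, among these compounds, hydrogen in place of fluoro on this aromatic carbon of the shared core gives a 1.7-fold higher number from compound 1 to compound 4 (0.22 log units; within the scatter) and so offers the first direct reading of this position. With the pentyl group on the nitrogen kept, losing this one heavy atom leaves a step no larger than repeated measurements of this kind can produce, so the fluoro is not shown to matter here. No measurement shown offers an explanation for this result.

The compounds shown leave open whether the same change would also stay within the scatter with the 4-methoxyphenyl group of compound 3 on the nitrogen. They also do not tell what a chloro, a nitrile or an amine on this same aromatic carbon would give.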